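The source may report more compounds than this note shows. Statements on the series, on what has been measured and on what is new or still open speak of the compounds shown alone.

Working notes on the series. In a functional assay on MCF7 cells (Homo sapiens) for inhibition, read by MTT assay, with a stated time of 48 h (a lower number here means a stronger inhibitor, a higher number a weaker inhibitor), compound 1 `COc1cc(-c2cc(/C=C/C(=O)c3ccc(Cl)c(Cl)c3)[nH]n2)cc(OC)c1OC` gives 3200 nM, compound 2 `COc1ccc(C(=O)/C=C/c2cc(-c3cc(OC)c(OC)c(OC)c3)n[nH]2)cc1OC` gives 510 nM and compound 3 `COc1cc(-c2cc(/C=C/C(=O)c3ccc(F)c(F)c3)[nH]n2)cc(OC)c1OC` gives 2500 nM. On these numbers compound 3 stands second highest of three: its nearest neighbour is compound 1 (a 1.3-fold lower number from compound 1 to compound 3 (0.11 log units; within the scatter)), its furthest is compound 2 (a 4.9-fold higher number from compound 2 to compound 3 (0.69 log units; beyond the scatter)). Compound 4 `COc1ccc(C(=O)/C=C/c2cc(-c3cc(OC)c(OC)c(OC)c3)n[nH]2)cc1F` differs from compound 3 by methoxy in place of fluoro on an aromatic carbon, which reads 3,4-difluorophenyl to 3-fluoro-4-methoxyphenyl. The step that bears on this is the one from the dimethoxyphenyl to the difluorophenyl ketone, above, and in the same sense a 6.3-fold lower number from compound 1 to compound 2 (0.80 log units; beyond the scatter). Exchanging only one fluoro for methoxy is expected to recover part of that gap, giving a modest step to a lower number, estimated as a 2.3-fold lower number from compound 3 to compound 4 (0.36 log units; beyond the scatter). Compound 4 is therefore expected at 1100 nM, with a range of 450 nM to 2700 nM.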

Compound 4, half-maximal inhibitory concentration: 3000 nM
Compound 4: middle estimate off by 2.7-fold (0.44 log units), on the low side, and the stated range ends below it.
By their numbers in this assay, from the lowest: compound 2; then compounds 3, 4 and 1 (each within the scatter of the next).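

In this assay, a methoxy on this aromatic carbon, para to a large group and ortho to a fluoro group, gives no readable change (a 1.2-fold higher number from compound 3 to compound 4 (0.08 log units; within the scatter)), and compound 4 also stays within the scatter of the 3,4-dichlorophenyl ketone (a 1.1-fold lower number from compound 1 to compound 4 (0.03 log units; within the scatter)). Among the compounds shown here, the full gap remains when the remaining fluoro is the only difference from compound 2 (a 5.9-fold higher number from compound 2 to compound 4 (0.77 log units; beyond the scatter)), so of these ketones only the 3,4-dimethoxyphenyl one stands apart. No supporting measurement accounts for this. Going by these compounds, whether that step is specific to methoxy stays open: a hydroxyl, an ethoxy or an amine in place of the remaining fluoro would test it.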